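The source may hold more compounds than are shown below. What is called first, only, known or untested is meant among the compounds shown, and "the series" means these compounds.

Three compounds share one core and differ only in the group on a six-membered aromatic ring of carbon only. Compound 1 `N[C@H](C(=O)NCc1ccc([N+](=O)[O-])cc1)[C@@H]1CC(Br)=NO1` carries a nitro group on that ring; in an ADME assay on HMEC-1 cells (Homo sapiens) for cytotoxicity, read by MTT assay, with a stated time of 72 h (a higher number here means a weaker inhibitor, a lower number a stronger inhibitor), compound 1 gives 36100 nM. Compound 2 `COc1ccc(CNC(=O)[C@@H](N)[C@@H]2CC(Br)=NO2)cc1` carries a methoxy group in the same position; in this assay compound 2 gives "not determined" (no result reported), so no single number places compound 2 on the scale, and the only measured anchor among these compounds is compound 1. Compound 3 `N[C@H](C(=O)NCc1ccccc1)[C@@H]1CC(Br)=NO1` takes the step onward from compound 2: hydrogen in place of methoxy on an aromatic carbon. Going by the values given here, no measured pair shows what hydrogen in place of methoxy on an aromatic carbon does in this assay, and compound 2 itself has no number to step from. The expectation can rest only on compound 1 and its value of 36100 nM. Given that, the change from compound 2 to compound 3 is expected to make no step in this assay beyond the scatter, in either direction. Compound 3 is therefore estimated to give about 40000 nM, within a range from 10000 nM to 150000 nM.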

Compound 3, half-maximal inhibitory concentration: 14900 nM
Beside the measured number, compound 3's estimate is 2.7-fold (0.43 log units) above it; measured number inside the range.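

In this assay the ring position now has its first real comparison, which shows a 2.4-fold lower number from compound 1 to compound 3 (0.38 log units; beyond the scatter) when hydrogen takes the place of nitro on an aromatic carbon, so the group held at this spot does move the reading, and with the nitro group gone the number falls, which on this scale means a stronger inhibitor of the cells. As far as these compounds go, the step from compound 2 to compound 3, the change actually predicted, cannot be read, as compound 2 has no number, and the effect of removing methoxy therefore remains unknown even though compound 3 now gives the shared core a second anchor on the scale. Nothing measured alongside these values speaks to why removing the nitro group lowers the number.

Going by these compounds alone, with only one readable step, no trend across groups at this position can be drawn, and a single pair cannot say whether the size of this step is typical of changes there. From the compounds shown here alone, how an amine, a carboxylic acid or a longer chain in the same place would compare with hydrogen and nitro stays open.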